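The compounds below may be only part of what the source reports. "The series", "measured", "known", "first", "only" and "open" are said of these compounds alone.

Compound 3 `Cc1cn([C@@H]2O[C@H](CO[Si](C)(C)C(C)(C)C)[C@@]3(OS(=O)(=O)C=C3NCC(=O)C(=O)N3CCC3)[C@H]2O[Si](C)(C)C(C)(C)C)c(=O)n(C)c1=O` gives 21600 nM in a functional assay on CCRF-CEM cells (Homo sapiens) (on this read-out lower numbers stand for higher toxicity in this test and higher numbers for lower toxicity in this test), the highest of the two numbers measured, with compound 1 `COC(=O)C(=O)CNC1=CS(=O)(=O)O[C@@]12[C@@H](CO[Si](C)(C)C(C)(C)C)O[C@@H](n1cc(C)c(=O)n(C)c1=O)[C@@H]2O[Si](C)(C)C(C)(C)C` as its nearest neighbour at 5570 nM, a step of a 3.9-fold higher number from compound 1 to compound 3 (0.59 log units; beyond the scatter). Compound 2 `COC(=O)CCNC1=CS(=O)(=O)O[C@@]12[C@@H](CO[Si](C)(C)C(C)(C)C)O[C@@H](n1cc(C)c(=O)n(C)c1=O)[C@@H]2O[Si](C)(C)C(C)(C)C` reports only a limit in this assay, > 250000 nM. Compound 4 `Cc1cn([C@@H]2O[C@H](CO[Si](C)(C)C(C)(C)C)[C@@]3(OS(=O)(=O)C=C3NCC(=O)O)[C@H]2O[Si](C)(C)C(C)(C)C)c(=O)n(C)c1=O` differs from compound 3 by hydroxy in place of (azetidin-1-yl)carbonyl on a carbonyl carbon. Among the measured compounds shown here, of the measured steps, only the one from compound 1 to compound 3, an exchange on the same carbonyl carbon, bears directly on this change, and it was modest, a 3.9-fold higher number from compound 1 to compound 3 (0.59 log units; beyond the scatter); the large steps of an at least 44-fold higher number from compound 1 to compound 2 (1.65 log units; beyond the scatter) and an at least 11-fold lower number from compound 2 to compound 3 (1.06 log units; beyond the scatter) alter the chain itself. He therefore expects for compound 4 a modest step in this assay of a 1.4-fold lower number from compound 3 to compound 4 (0.16 log units; within the scatter), with no firm direction, estimating 15000 nM within 3000 nM to 100000 nM.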

Compound 4, half-maximal cytotoxic concentration: 65000 nM
Estimate against measurement, compound 4: 4.3-fold (0.64 log units) below, and the stated range covers the measured number.
By their numbers in this assay, from the lowest: compound 1; then compound 3; then compound 4. At a limit, above all of these: compound 2.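

Hydroxy on this carbonyl carbon gives a higher number in this assay than either group it was compared with: in place of (azetidin-1-yl)carbonyl the result is a 3.0-fold higher number from compound 3 to compound 4 (0.48 log units; beyond the scatter), and in place of methoxycarbonyl it is a 12-fold higher number from compound 1 to compound 4 (1.07 log units; beyond the scatter). The carboxy end therefore carries the highest of the three exact numbers in the series. The chain with the saturated ester still stands higher, though that end is only a limit: an at least 3.8-fold lower number from compound 2 to compound 4 (0.58 log units; beyond the scatter).

The compounds shown leave open where a primary amide or a piperidin-1-yl amide on this carbonyl carbon would fall. They also leave open whether a longer chain ending in a carboxylic acid would move the number further.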